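Notes on compound 4: tert-butoxy in place of oxolan-2-yl

The source may hold more compounds than are shown below. What is called first, only, known or untested is meant among the compounds shown, and "the series" means these compounds.

In an assay on CHO-K1 cells for displacement of a labelled ligand from prostaglandin E2 receptor EP1 subtype (Homo sapiens) (a higher number here means a weaker inhibitor, a lower number a stronger inhibitor), compound 1 `CNC(=O)c1cc(C)n(Cc2cc(Cl)ccc2OCc2ccccc2)n1` gives 100 nM, compound 2 `Cc1cc(C(=O)Nc2c(F)cccc2F)nn1Cc1cc(Cl)ccc1OCc1ccccc1` gives 10 nM, and compound 3 `Cc1cc(NC(=O)C2CCCO2)nn1Cc1cc(Cl)ccc1OCc1ccccc1` gives 39.8 nM. Compound 3 thus sits second highest of the three numbers, with a 2.5-fold lower number from compound 1 to compound 3 (0.40 log units; beyond the scatter) and a 4.0-fold higher number from compound 2 to compound 3 (0.60 log units; beyond the scatter). Compound 4 `Cc1cc(NC(=O)OC(C)(C)C)nn1Cc1cc(Cl)ccc1OCc1ccccc1` differs from compound 3 only by tert-butoxy in place of oxolan-2-yl on a carbonyl carbon. Among the measured compounds shown here, no measured step alters the group on this carbonyl carbon: a 10-fold lower number from compound 1 to compound 2 (1.00 log units; beyond the scatter) and the other two steps exchange the whole amide-type side chain instead. The step from compound 3 to compound 4 is therefore unanchored by precedent, and no step beyond the scatter is expected: a 1.0-fold higher number from compound 3 to compound 4 (0.00 log units; within the scatter). Compound 4 is estimated at 40 nM, with a range from 15 nM to 120 nM.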

Compound 4, half-maximal inhibitory concentration: 25.1 nM
The estimate for compound 4 lay 1.6-fold (0.20 log units) above the measured number; measured number inside the range.
By their numbers in this assay, from the lowest: compound 2; then compounds 4 and 3 (each within the scatter of the next); then compound 1.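

In this assay, the open tert-butoxy and the ring-bearing oxolan-2-yl on this carbonyl carbon cannot be told apart (a 1.6-fold lower number from compound 3 to compound 4 (0.20 log units; within the scatter)), so at this place, among these two groups, the ring is not needed for the value. The (tert-butoxycarbonyl)amino side chain still stands apart from the other two amide-type side chains (a 4.0-fold lower number from compound 1 to compound 4 (0.60 log units; beyond the scatter); a 2.5-fold higher number from compound 2 to compound 4 (0.40 log units; beyond the scatter)). Nothing on hand accounts for these results. As far as these compounds go, whether a smaller methyl, a phenyl or an amine on this carbonyl carbon would hold the value remains open.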